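Sulfamate series: pyridyl to fluorobenzyl swap

The source may report more compounds than this note shows. Statements on the series, on what has been measured and on what is new or still open speak of the compounds shown alone.

Measured compounds
- compound 1, `NS(=O)(=O)Oc1ccc2c(c1)CN(C(=O)c1cccc(N(Cc3ccccc3)Cc3ccco3)c1)CC2`: 90.5%
- compound 2, `CCN(Cc1cccnc1)c1ccc(C(=O)N2CCc3ccc(OS(N)(=O)=O)cc3C2)cc1`: 85.2%

In an assay on HEK293 cells for inhibition of Steryl-sulfatase (Homo sapiens), tested at 1 uM (a lower number here means a weaker effect, a higher number a stronger effect of the compound at the concentration tested), compound 2 gives 85.2% and so stands as the lowest of the two numbers shown, though compound 1 with 90.5% lies within the scatter of it, so no order between them is claimed. Compound 3, `CCN(Cc1ccc(F)cc1)c1ccc(C(=O)N2CCc3ccc(OS(N)(=O)=O)cc3C2)cc1`, differs from compound 2 by 4-fluorophenyl in place of pyridin-3-yl on a saturated chain carbon bound to a nitrogen on an aromatic ring. Within the data shown here, no step between measured compounds is available to guide this change. As both measured numbers are high and close, the expected step of a number 0.2 percentage points lower from compound 2 to compound 3 (within the scatter) is none beyond the scatter. Compound 3 is estimated at 85%, within a range from 70% to 95%.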

Compound 3, a percentage reported as inhibition, at one concentration (the size of the read-out at that concentration, not a potency): 91.2%
The estimate for compound 3 lay 6.2 percentage points below the measured number; low and high end bracket the measured number.
By their numbers in this assay, from the lowest: compounds 2, 1 and 3 (each within the scatter of the next).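

In this assay, among these compounds, the replacement reads as a number 6 percentage points higher from compound 2 to compound 3 (within the scatter) and gives the first one-place comparison. On a saturated chain carbon bound to a nitrogen on an aromatic ring, 4-fluorophenyl is tolerated in place of pyridin-3-yl, so the high read-out does not depend on the hydrogen-bond acceptor that leaves with pyridin-3-yl. Nothing available explains this result.

Open, as far as these compounds go, is whether a basic amine or a carboxylic acid on that benzyl ring would keep the read-out. Also open, from the compounds shown here alone, is whether a longer chain in place of ethyl would do so.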